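Aryl sulfonamide variation in a shared-core series

A few compounds are considered here, and "the series" means these few. Any claim that something is new, unique, unknown or untested is made for them only; others in the source may bear on it.

Measured so far:
compound 1, `Cc1ccccc1S(=O)(=O)NCc1ccc(CNC(=O)c2cccnc2)cc1` — 1000 nM in an assay on MDA-MB-231 cells for displacement of a labelled ligand from C-X-C chemokine receptor type 4 (Homo sapiens), read by fluorescence and microscopy, with stated times of 10 min and 30 min; a higher number here means that more compound is needed for the effect, a lower number that less compound is needed
compound 2, `O=C(NCc1ccc(CNS(=O)(=O)c2cccc3ccccc23)cc1)c1cccnc1` — 1000 nM in this assay

For the measured compounds named here, compound 2 stands level with compound 1 on these numbers; the single measured step, no change at the digits printed from compound 1 to compound 2 (within the scatter), lies within the scatter. Compound 3, `O=C(NCc1ccc(CNS(=O)(=O)c2cccc(F)c2)cc1)c1cccnc1`, is the next member. Relative to compound 2 it carries the change (3-fluorophenyl in place of naphthalen-1-yl on a sulfonyl sulfur).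

Going by the values given here, only one step bears on this change: the earlier exchange of one aryl group for another on the sulfonyl sulfur, no change at the digits printed from compound 1 to compound 2 (within the scatter), produced nothing beyond the scatter. The present change again exchanges one aryl group for another at the same place, so no shift beyond the scatter is expected in this assay, with a step estimated as no change at the digits printed from compound 2 to compound 3 (within the scatter). Compound 3 is accordingly expected to give 1000 nM in this assay, within 450 nM to 2200 nM.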

Compound 3, effective concentration (reported as EC, without a stated level of effect): 1000 nM
Beside the measured number, compound 3's estimate shows no gap at the digits printed; low and high end bracket the measured number.
By their numbers in this assay, from the lowest: compounds 1, 2 and 3 (each within the scatter of the next).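

The step from naphthalen-1-yl to 3-fluorophenyl on a sulfonyl sulfur replaces two six-membered aromatic rings of carbon only with one and brings in fluorine, and in this assay it reads as no change at the digits printed from compound 2 to compound 3 (within the scatter) with no shift to record. Set against the methyl-bearing group, the same group gives no change at the digits printed from compound 1 to compound 3 (within the scatter) in this reading, so three different aryl groups at this place, on the shared core, now lie within the scatter of one another. No supporting data bear on why these aryl exchanges leave the reading flat.

Open, from the compounds shown here alone, is whether this flat reading holds only among aryl groups or also extends to a carboxylic acid, an amine or a longer chain on the sulfonyl sulfur. Also open, going by these compounds, is whether any group at this place moves the value beyond the scatter.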